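Swapping a Thiophene for a Pyridine on the Shared Core

The source may report more compounds than this note shows. Statements on the series, on what has been measured and on what is new or still open speak of the compounds shown alone.

Compound 3 `COc1nc(-c2ccsc2)ccc1[C@@H](c1ccccc1)[C@@](O)(CCN(C)C)c1cccc2ccccc12` was tested in a toxicity assay on Vero cells (Chlorocebus sabaeus) for cytotoxicity (a higher number here means that more compound is tolerated, a lower number that less compound is tolerated), where compound 3 gives 24.4 ug/mL. Among the two plain numbers available, that of compound 3 stands lowest, though the step to its nearest neighbour, compound 1 `COc1nc(-c2cnsc2)ccc1[C@@H](c1ccccc1)[C@@](O)(CCN(C)C)c1cccc2ccccc12`, is a 1.1-fold lower number from compound 1 to compound 3 (0.03 log units; within the scatter), so the two are indistinguishable here. In this assay compound 1 gives 26.3 ug/mL. Compound 2 `COc1ccc(-c2ccc([C@@H](c3ccccc3)[C@@](O)(CCN(C)C)c3cccc4ccccc34)c(OC)n2)cc1` reached only a limit of the assay, > 50 ug/mL, as recorded in the limit of > 50 ug/mL in this assay, at which 1 of the 3 values shown sits. The remaining measured steps are an at least 2.0-fold lower number from compound 2 to compound 3 (0.31 log units; beyond the scatter) and an at least 1.9-fold higher number from compound 1 to compound 2 (0.27 log units; that floor lies within the scatter).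

Compound 4 `COc1nc(-c2ccncc2)ccc1[C@@H](c1ccccc1)[C@@](O)(CCN(C)C)c1cccc2ccccc12` has not yet been measured. It differs from compound 3 in one place: pyridin-4-yl in place of thiophen-3-yl on an aromatic carbon. The step bearing most on this is an at least 2.0-fold lower number from compound 2 to compound 3 (0.31 log units; beyond the scatter), where a six-membered aromatic ring stood in place of thiophen-3-yl, while the step of a 1.1-fold lower number from compound 1 to compound 3 (0.03 log units; within the scatter), between two five-membered rings, stayed within the scatter. A modest rise is therefore expected, a 1.3-fold higher number from compound 3 to compound 4 (0.12 log units; within the scatter). Compound 4 is estimated at 32 ug/mL, within a range from 16 ug/mL to 50 ug/mL.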

Compound 4, half-maximal cytotoxic concentration: > 50 ug/mL
Compound 4 was reported as a limit; the forecaster's own chance of this, stated with the estimate: 25%; at least 1.5-fold (0.19 log units) between middle value and limit.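

At this position, on the aromatic carbon next to the ring nitrogen, the higher number seen with 4-methoxyphenyl in compound 2 is not confined to that group, since pyridin-4-yl also gives one in this assay: the result is an at least 2.0-fold higher number from compound 3 to compound 4 (0.31 log units; beyond the scatter). The comparison with the other five-membered ring points the same way, an at least 1.9-fold higher number from compound 1 to compound 4 (0.27 log units; that floor lies within the scatter), although that floor is still within the scatter. Among these four compounds, both six-membered aromatic rings, in compound 2 and compound 4, now end at a reported limit rather than a plain number, and neither five-membered ring does: the limit of > 50 ug/mL in this assay, at which 2 of the 4 values shown sit.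

On these data alone, the step between compound 2 and compound 4 cannot be read, and how far either compound lies past the limit stays unknown. Also open, as far as these compounds go, is whether an unsubstituted phenyl ring, or a pyridine ring carrying an amine, would reach the same limit at this position.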